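Acute toxicity notes: chloro to methyl on the aryl ring

This account rests on a few compounds, and the source may have more. Where it says the series, first, only, none or still open, it means among the compounds named here.

Compound 1 `COc1ccc(/C(C)=C(/C)C(=O)NC2CC2)cc1`: 300 mg/kg
Compound 2 `C=CCNC(=O)/C(C)=C(\C)c1cc(OC)c(OC)c(OC)c1`: 110 mg/kg
Compound 3 `C#CCNC(=O)/C(C)=C(\C)c1ccc(Cl)cc1`: 60 mg/kg

All three numbers come from a toxicity assay on the whole organism (strain Icem-CET (SPF Caw)) for cytotoxicity, with Mus musculus as the target; a lower number here means that less compound is needed, a higher number that more compound is needed for the effect. Compound 3 gives the lowest number of the three; compound 2 stands within the scatter of it, while compound 1 lies beyond the scatter at a higher dose. Compound 4 `C#CCNC(=O)/C(C)=C(\C)c1ccc(C)cc1` differs from compound 3 by methyl in place of chloro on an aromatic carbon. Among the measured compounds shown here, no pair of measured compounds shows this change, so its size cannot be drawn from the series. In this assay the step from compound 3 to compound 4 is expected to stay within the scatter, a 1.2-fold higher number from compound 3 to compound 4 (0.07 log units; within the scatter). Compound 4 is therefore estimated at 70 mg/kg, with a range from 35 mg/kg to 140 mg/kg.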

Compound 4, dose for half-maximal effect: 120 mg/kg
Compound 4: middle estimate off by 1.7-fold (0.23 log units), on the low side; the range from low to high includes it.
By their numbers in this assay, from the lowest: compounds 3, 2 and 4 (each within the scatter of the next); then compound 1.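

In this assay, among the compounds shown here, methyl in place of chloro on an aromatic carbon, para to a large group, gives a 2.0-fold higher number from compound 3 to compound 4 (0.30 log units; within the scatter) and supplies the first comparison of compounds differing in one place. At this position, the two groups are not separated by the assay, and the step says nothing about a direction. Open, from the compounds shown here alone, is whether a carboxylic acid or an amine at this place would reach beyond the scatter, and whether the same change reads alike on the cores of compound 1 and compound 2. No measurement at hand speaks to what lies behind this step.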